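The compounds below may be only part of what the source reports. "The series", "measured", "known", "first", "only" and "open" are said of these compounds alone.

In a functional assay on L1210 cells (Mus musculus) for cytotoxicity, read by MTT assay, with a stated time of 24 h (on this read-out lower numbers stand for stronger inhibition and higher numbers for weaker inhibition), compound 1 (`COc1cc(C(=O)/C=C/c2ccc(Cl)cc2)cc(OC)c1OC`) gives 44500 nM and compound 2 (`COc1cc(C(=O)/C=C/c2c(Cl)cccc2Cl)cc(OC)c1OC`) gives 50500 nM, so the two stand level within the scatter. Compound 3 (`COc1cc(C(=O)/C=C/c2ccc(Br)cc2)cc(OC)c1OC`) changes compound 2 at one place: 4-bromophenyl in place of 2,6-dichlorophenyl on a double-bonded chain carbon bound to a double-bonded chain carbon. For the measured compounds named here, the one measured step at this place, a 1.1-fold higher number from compound 1 to compound 2 (0.05 log units; within the scatter), also involves 2,6-dichlorophenyl and stays within the scatter. Going by the values given here, no 4-bromophenyl compound has been measured, so this rests on a single step. No change beyond the scatter is expected in this assay, and the estimated step is a 1.2-fold lower number from compound 2 to compound 3 (0.08 log units; within the scatter). For compound 3 the estimated value is 42000 nM, with an expected range of 20000 nM to 85000 nM.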

Compound 3, half-maximal inhibitory concentration: > 100000 nM
Compound 3: only a limit was reported (the forecaster's own chance of this, stated with the estimate: 5%); middle value at least 2.3-fold (0.37 log units) from the limit.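

In this assay compound 3 is reported only as a limit, not a number: the limit of > 100000 nM in this assay, at which 1 of the 3 values shown sits. Bromo in place of chloro on an aromatic carbon gives an at least 2.2-fold higher number from compound 1 to compound 3 (0.35 log units; beyond the scatter), so this position, which showed no change beyond the scatter in the earlier step, does respond to the change from chloro to bromo. The reading against the 2,6-dichlorophenyl compound is less firm, with only a floor: an at least 1.9-fold higher number from compound 2 to compound 3 (0.29 log units; that floor lies within the scatter).

Still open, going by these compounds, are the true value of compound 3 and whether 4-fluorophenyl or 4-aminophenyl at this place would stay level with compound 1.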